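The source may report more compounds than this note shows. Statements on the series, on what has been measured and on what is new or still open speak of the compounds shown alone.

Working notes on the series. Compound 1 `COc1cccc(Nc2ncc(C)c(Nc3nc4ccccc4s3)n2)c1` and compound 2 `COc1ccc(Nc2ncc(C)c(Nc3nc4ccccc4s3)n2)cc1` share one core and differ only in the methoxyphenyl on the nitrogen. In a functional assay on MCF7 cells (Homo sapiens) for antiproliferative activity, read by MTT assay, with a stated time of 48 h (a lower number here means a stronger inhibitor, a higher number a weaker inhibitor), compound 1 gives > 50000 nM, which is a limit of the assay and not a number. In this assay compound 2 gives > 50000 nM, again only a limit. The step that the two limits leave unreadable from compound 1 to compound 2 is unreadable because both ends sit at the limit of > 50000 nM in this assay, at which 2 of the 2 values shown sit. Compound 2 therefore stands at a limit, and no ordering of the two measured compounds is possible.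

Compound 3 `Cc1cnc(Nc2cccc(F)c2)nc1Nc1nc2ccccc2s1` is unmeasured; it differs from compound 2 by 3-fluorophenyl in place of 4-methoxyphenyl on a nitrogen on an aromatic ring. For the measured compounds named here, no measured step bears directly on this exchange; the single available step is unreadable, so no size or direction of step in this assay can be drawn from it. With both measured compounds at the limit, compound 3 is expected to give about 60000 nM, with a range from 20000 nM to 200000 nM. The step this estimate means is a step that the limit leaves unreadable from compound 2 to compound 3, expected to lie within the scatter.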

Compound 3, half-maximal inhibitory concentration: > 50000 nM
Compound 3: no number, only a limit (the forecaster's own chance of this, stated with the estimate: 80%); the middle value is on the limit's open side.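

For the compounds shown here, no step among compound 1, compound 2 and compound 3 can be read, because all three sit at a limit and give no number: (the limit of > 50000 nM in this assay, at which 3 of the 3 values shown sit). The compounds shown leave open how the 4-methoxyphenyl, 3-methoxyphenyl and 3-fluorophenyl groups rank in this assay, and what on the shared core would give a readable value there.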